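The source may report more compounds than this note shows. Statements on the series, on what has been measured and on what is new or still open speak of the compounds shown alone.

Measured so far:
compound 1, `O=C(/C=C/c1cn(-c2ccccc2)nc1-c1ccncc1)c1ccsc1`, 2200 nM
compound 2, `COc1cc(OC)c(C(=O)/C=C/c2cn(-c3ccccc3)nc2-c2ccncc2)c(OC)c1`, 2600 nM

In a functional assay on Huh-7 cells (Homo sapiens) for inhibition, read by sulforhodamine B assay, with a stated time of 72 h (a lower number here means a stronger inhibitor, a higher number a weaker inhibitor), compound 2 gives 2600 nM, the higher of the two numbers, while compound 1 gives 2200 nM; the two lie within the usual scatter of each other. Compound 3 is `COc1ccc(C(=O)/C=C/c2cn(-c3ccccc3)nc2-c2ccncc2)c(OC)c1`. It differs from compound 2 by hydrogen in place of methoxy on an aromatic carbon. Within the data shown here, no measured pair shows a step of this kind, so no direction can be read from the data, and a change not beyond the scatter is expected. For compound 3 the value in this assay is estimated at 2500 nM, between 1000 nM and 6500 nM. The expected step of a 1.0-fold lower number from compound 2 to compound 3 (0.02 log units; within the scatter) is small.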

Compound 3, half-maximal inhibitory concentration: 4400 nM
Estimate against measurement, compound 3: 1.8-fold (0.25 log units) below, within the range that was stated.
By their numbers in this assay, from the lowest: compounds 1, 2 and 3 (each within the scatter of the next).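

In this assay, hydrogen in place of methoxy on the aromatic carbon ortho to a large group gives a 1.7-fold higher number from compound 2 to compound 3 (0.23 log units; within the scatter), so this methoxy can go without a change that stands clear of the scatter. The 2,4-dimethoxyphenyl in place of thiophen-3-yl on the carbonyl carbon gives a 2.0-fold higher number from compound 1 to compound 3 (0.30 log units; within the scatter), which also stays inside the scatter. Nothing available bears on the reason for these numbers. Open remains whether an amine or a hydroxyl group on this same carbon would move the number beyond the scatter.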